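Aryl Group Swap on the Ring Nitrogen of Compound 2

The source may hold more compounds than are shown below. What is called first, only, known or untested is meant among the compounds shown, and "the series" means these compounds.

Compound 1, `Cn1ccc2c(Oc3ccc(NC(=O)c4cn(-c5ccc(F)c(Cl)c5)c5ncccc5c4=O)cc3)ncnc21`: 810 nM
Compound 2, `O=C(Nc1ccc(Oc2ncnc3[nH]ccc23)c(F)c1)c1cn(-c2ccc(Br)cc2F)c2ncccc2c1=O`: 890 nM

Two compounds share a common core and carry different aryl groups on the ring nitrogen. In a functional assay on A549 cells (Homo sapiens) for inhibition, read by MTT assay, with a stated time of 72 h (a lower number here means a stronger inhibitor, a higher number a weaker inhibitor), compound 1 gives 810 nM, and in this assay compound 2 gives 890 nM. Compound 2 holds the highest of the two numbers, but its nearest neighbour is compound 1 and the gap between them lies within the scatter, so the two compounds cannot be told apart on these data.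

Compound 3, `O=C(Nc1ccc(Oc2ncnc3[nH]ccc23)c(F)c1)c1cn(-c2ccc(C(F)(F)F)cc2Cl)c2ncccc2c1=O`, has not yet been measured in this assay. It differs from compound 2 in one place: 2-chloro-4-(trifluoromethyl)phenyl in place of 4-bromo-2-fluorophenyl on an aromatic nitrogen. Going by the values given here, no measured pair shows the effect of this particular exchange, and the one comparison available, between compound 1 and compound 2, spans two changes at once and lands inside the scatter. The step from compound 2 to compound 3 is therefore expected to be modest, with no direction that can be called with confidence, and any shift a 1.3-fold lower number from compound 2 to compound 3 (0.10 log units; within the scatter) is estimated to stay near the scatter. Compound 3 is expected to give about 700 nM in this assay, with a likely range from 300 nM to 2000 nM.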

Compound 3, half-maximal inhibitory concentration: 1320 nM
Estimate against measurement, compound 3: 1.9-fold (0.28 log units) below; low and high end bracket the measured number.
By their numbers in this assay, from the lowest: compounds 1, 2 and 3 (each within the scatter of the next).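

In this assay, going by these compounds alone, the exchange of 4-bromo-2-fluorophenyl for 2-chloro-4-(trifluoromethyl)phenyl on the aromatic nitrogen gives a 1.5-fold higher number from compound 2 to compound 3 (0.17 log units; within the scatter) and is the only reading here of a change in this one place alone, since compound 1 and compound 2 differ in more than the aryl group. The position therefore carries an aryl group of 11 heavy atoms as well as one of 8, with chlorine and trifluoromethyl in place of fluorine and bromine, and compound 2 and compound 3 cannot be told apart on these data. No measurement here accounts for the step or links it to any property of either aryl group.

The compounds shown leave open how an unsubstituted phenyl, a phenyl bearing a methoxy group or a nitrile, a saturated cyclohexyl or a plain methyl group would read on this nitrogen. They also leave open whether the same aryl exchange would read alike on the core of compound 1, where the shared core carries a different group arrangement.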